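The source may hold more compounds than are shown below. What is called first, only, known or untested is meant among the compounds shown, and "the series" means these compounds.

Measured compounds:
- compound 1 `NC(=O)c1c(NC(=O)c2ccccc2Cl)sc2c1CCN(C(=S)Nc1ccccc1)C2` — 15600 nM
- compound 2 `Cc1ccccc1NC(=S)N1CCc2c(sc(NC(=O)c3ccccc3Cl)c2C(N)=O)C1` — 11700 nM

In a functional assay on MKN-74 cells (Homo sapiens) for antiproliferative activity, with a stated time of 24 h (a higher number here means a weaker inhibitor, a lower number a stronger inhibitor), compound 1 gives 15600 nM, the highest of the two numbers; its nearest neighbour is compound 2, which in this assay gives 11700 nM. The two differ only on one aromatic carbon of the thiourea-bound ring, and the step of a 1.3-fold lower number from compound 1 to compound 2 (0.12 log units; within the scatter) stays within the scatter, so the two values show no difference that can be read.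

Compound 3 `NC(=O)c1c(NC(=O)c2ccccc2)sc2c1CCN(C(=S)Nc1ccccc1)C2` has not yet been measured. It differs from compound 1 in that (hydrogen in place of chloro on an aromatic carbon). Within the data shown here, no measured step touches the benzamide ring; the only step known, from compound 1 to compound 2, changes a different ring and was within the scatter. There is thus nothing in the data that points to a change in either direction for removing the chloro, and the expectation for this assay is no step beyond the scatter, with the estimated step of a 1.2-fold higher number from compound 1 to compound 3 (0.06 log units; within the scatter). Compound 3 is therefore expected to give about 18000 nM, with a range from 8000 nM to 40000 nM.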

Compound 3, half-maximal inhibitory concentration: > 50000 nM
Compound 3: only a limit was reported; the forecaster's own chance of this, stated with the estimate: 15%; middle value at least 2.7-fold (0.44 log units) from the limit.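

In this assay, the change from 2-chlorophenyl to phenyl gives an at least 3.2-fold higher number from compound 1 to compound 3 (0.50 log units; beyond the scatter), the first step among the compounds shown that lies beyond the scatter. Among these compounds, the only earlier step, methyl in place of hydrogen on the thiourea-bound ring, stayed within the scatter, so this aromatic carbon, ortho to a large group, is the first place where a single change visibly moves the read-out, and the chloro counts for more here than the absence of any earlier effect could suggest. Going by these compounds, the value of compound 3 is a limit and not a number, so the step gives only a lower bound and its full size stays unknown: the limit of > 50000 nM in this assay, at which 1 of the 3 values shown sits.

The compounds shown carry only chloro or hydrogen at this place, so it stays open whether a fluoro, a methyl, a methoxy or an amine there would keep the level of compound 1 at 15600 nM. On these data alone, it also stays open whether a chloro on another carbon of the same ring would do so, and whether removing the chloro from compound 2 would give a step of similar size.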